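Ethoxy to cyclopropylmethoxy: a small step expected

The compounds below may be only part of what the source reports. "The series", "measured", "known", "first", "only" and "open" are said of these compounds alone.

In an ADME assay on the whole organism (Mus musculus, strain CD1) for pharmacokinetics, read by LC-MS, with a stated time of 24 h, at a dose of 1 mg/kg by the intravenous route (a higher number here means that more of the compound sits outside the plasma, a lower number that more of the compound stays in the plasma), compound 1 `CCOc1cc2[nH]c(Cc3nn(CC(=O)O)c(=O)c4ccccc34)nc2cc1Cl` gives 0.5 L/kg and holds the middle of three values. Compound 2 `O=C(O)Cn1nc(Cc2cn3cc(OCC4CC4)c(Cl)cc3n2)c2ccccc2c1=O` gives 0.28 L/kg and lies within the scatter of compound 1. Compound 3 `C[C@H](C(=O)O)n1nc(Cn2cc3cc(OCC4CC4)c(Cl)cc3n2)c2ccccc2c1=O` gives 1.9 L/kg and stands higher than compound 1 by a gap beyond the scatter.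

Compound 4 `O=C(O)Cn1nc(Cc2nc3cc(Cl)c(OCC4CC4)cc3[nH]2)c2ccccc2c1=O` departs from compound 1 in one place: cyclopropyl in place of methyl on a saturated chain carbon bound to an oxygen on an aromatic ring (cyclopropyl in place of methyl on a saturated chain carbon bound to an oxygen on an aromatic ring, or ethoxy to cyclopropylmethoxy).

Within the data shown here, no measured pair shows this change alone. Compounds 2 and 3 both carry cyclopropylmethoxy, yet compound 2 at 0.28 L/kg and compound 3 at 1.9 L/kg lie far apart, so they set no direction. The change is therefore expected to produce no step beyond the scatter in this assay and at most a slight rise, with the estimated step of a 1.1-fold higher number from compound 1 to compound 4 (0.04 log units; within the scatter) remaining small. For compound 4 the estimated value is 0.55 L/kg with an expected range from 0.27 L/kg to 1.1 L/kg in this assay.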

Compound 4, volume of distribution at steady state: 1 L/kg
Compound 4: the middle estimate sits 1.8-fold (0.26 log units) below what was measured; low and high end bracket the measured number.
By their numbers in this assay, from the lowest: compounds 2, 1, 4 and 3 (each within the scatter of the next, the first and the last beyond it).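

Among these compounds, the step of a 2.0-fold higher number from compound 1 to compound 4 (0.30 log units; within the scatter) is the first direct reading of this change, since compounds 2 and 3 differ from compound 1 in more than one place. In this assay, replacing methyl with cyclopropyl on a saturated chain carbon bound to an oxygen on an aromatic ring therefore gives no step beyond the scatter on the core of compound 1. This rests on a single pair, and nothing available accounts for the size of the step.

The compounds shown leave open how a methoxy group, a longer chain such as butoxy, or an amine at this place would read in this assay. They also leave open whether ethoxy to cyclopropylmethoxy would stay within the scatter on another core.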